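Three Analogues at the Assay Limit and a Fourth

This account rests on a few compounds, and the source may have more. Where it says the series, first, only, none or still open, it means among the compounds named here.

Three compounds share a core and differ only in the groups on a six-membered aromatic ring. Compound 1 `Oc1ccccc1CNc1ncnc2c1ncn2C1CCCCO1` carries a hydroxy group there, compound 2 `COc1cccc(CNc2ncnc3c2ncn3C2CCCCO2)c1O` adds a methoxy group, and compound 3 `COc1ccc(CNc2ncnc3c2ncn3C2CCCCO2)cc1OC` carries two methoxy groups. All were tested in an ADME assay on MCF7 cells (Homo sapiens) for cytotoxicity, with a stated time of 72 h; on this read-out higher numbers stand for weaker inhibition and lower numbers for stronger inhibition. In this assay compound 1 reaches only > 100000 nM, which is a limit of the assay rather than a number. Compound 2 likewise gives only the limit > 100000 nM. Compound 3 also stops at the limit > 100000 nM. The change methoxy in place of hydrogen on an aromatic carbon yields a step that the two limits leave unreadable from compound 1 to compound 2, which follows from the limit of > 100000 nM in this assay, at which 3 of the 3 values shown sit. The difference between the cores of compound 1 and compound 3 is not broken down here.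

Compound 4 `COc1cc(OC)c(OC)cc1CNc1ncnc2c1ncn2C1CCCCO1` is the next member; the change is methoxy in place of hydrogen on an aromatic carbon. This is the same kind of change as from compound 1 to compound 2, but the surroundings differ: in compound 2 the methoxy sits ortho to a hydroxy group and meta to a large group, whereas in compound 4 it sits ortho to a large group, meta to a methoxy group and para to a methoxy group. The earlier step is unreadable, and the limit of > 100000 nM in this assay, at which 3 of the 3 values shown sit, leaves no room for a readable one, so the expected step is a step that the limit leaves unreadable from compound 3 to compound 4 in this assay. Compound 4 is therefore estimated at 150000 nM, most likely reported again only as a limit.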

Compound 4, half-maximal inhibitory concentration: > 100000 nM
Compound 4 was reported as a limit (the forecaster's own chance of this, stated with the estimate: 85%); the middle value is on the limit's open side.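

Compound 4 gives > 100000 nM in this assay, which is a limit and not a number. The step from compound 3 to compound 4 therefore cannot be read, since both compounds stop at a limit: the limit of > 100000 nM in this assay, at which 4 of the 4 values shown sit. The compounds shown leave open whether any change to the groups on the aromatic ring would give a measurable value in this assay.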